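The compounds below may be only part of what the source reports. "The series", "measured", "known", "first", "only" and "open" are said of these compounds alone.

Compound 3 `C=CCc1cc(C(C)=O)c(O)cc1OCCCCCCCC#N` was tested in an assay on isolated protein for binding affinity to leukotriene B4 receptor 1 (Homo sapiens), tested at 1 uM (on this read-out higher numbers stand for more inhibition at the one concentration tested (going by the name of the read-out) and lower numbers for less inhibition), and gives 52%. Compound 1 `C=CCc1cc(C(C)=O)c(O)cc1OCCCC#N` gives 6%, and compound 2 `C=CCc1cc(C(C)=O)c(O)cc1OCCCCCCC#N` gives 63%; compound 3 thus stands second highest of the three, as the steps of a number 46 percentage points higher from compound 1 to compound 3 (beyond the scatter) and a number 11 percentage points lower from compound 2 to compound 3 (beyond the scatter) show. Compound 4 `C=CCc1cc(C(C)=O)c(O)cc1OCCCCCCCCC#N` differs from compound 3 by cyanomethyl in place of cyano on a saturated chain carbon, seven bonds along the chain from an oxygen on an aromatic ring. Lengthening this chain from its shortest form gave a number 57 percentage points higher from compound 1 to compound 2 (beyond the scatter) and a number 46 percentage points higher from compound 1 to compound 3 (beyond the scatter), but the closest comparable step, a number 11 percentage points lower from compound 2 to compound 3 (beyond the scatter), was a modest fall. A further modest fall is therefore expected for compound 4, roughly a number 12 percentage points lower from compound 3 to compound 4 (beyond the scatter). Compound 4 is expected to give about 40% in this assay, within a range from 20% to 60%.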

Compound 4, a percentage reported as inhibition, at one concentration (the size of the read-out at that concentration, not a potency): 50%
Estimate against measurement, compound 4: 10 percentage points below; measured number inside the range.
By their numbers in this assay, from the lowest: compound 1; then compounds 4 and 3 (each within the scatter of the next); then compound 2.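

One more chain carbon at this position gives (a number 2 percentage points lower from compound 3 to compound 4 (within the scatter)), so the fall seen on going from compound 2 to compound 3 does not carry on here. The longest chain shown keeps most of the gain over the shortest chain (a number 44 percentage points higher from compound 1 to compound 4 (beyond the scatter)), yet it still stays short of the highest number in the series (a number 13 percentage points lower from compound 2 to compound 4 (beyond the scatter)). Nothing available explains why the read-out follows the chain in this way. Still open, on these data alone, is what a longer chain would give, and whether a carboxylic acid in place of the nitrile would keep the inhibition.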